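Working notes: from compound 2 to compound 3

The compounds below may be only part of what the source reports. "The series", "measured", "known", "first", "only" and "open" are said of these compounds alone.

Values in a toxicity assay on HepG2 2.2.15 cells (Homo sapiens) for cytotoxicity, read by CellTiter-Glo (on this read-out lower numbers stand for higher toxicity in this test and higher numbers for lower toxicity in this test), so far
- Compound 1 `CC1(C)CC(=O)N(c2cnn3c2CN(C(=O)Nc2cc(F)c(F)c(F)c2)C(C2CC2)C3)C1`: 115000 nM
- Compound 2 `Cc1cnc(C2CC(=O)N(c3cnn4c3CN(C(=O)Nc3cc(F)c(F)c(F)c3)C(C3CC3)C4)C2)s1`: 96200 nM

For the measured compounds named here, compound 2 lies within the scatter of compound 1, the only other measured compound. Compound 3 `O=C(Nc1cc(F)c(F)c(F)c1)N1Cc2c(-c3ccc(F)cc3)cnn2CC1C1CC1` carries 4-fluorophenyl in place of 4-(5-methyl-1,3-thiazol-2-yl)-2-oxopyrrolidin-1-yl on an aromatic carbon. Going by the values given here, the only measured step at this place (a 1.2-fold lower number from compound 1 to compound 2 (0.08 log units; within the scatter)) stayed within the scatter, but no measured compound carries 4-fluorophenyl there, so it bears only loosely on this change. In this assay the expected step is modest and towards a lower number (a 2.1-fold lower number from compound 2 to compound 3 (0.33 log units; beyond the scatter)). Compound 3 is estimated at 45000 nM (15000 nM to 110000 nM).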

Compound 3, half-maximal cytotoxic concentration: 38500 nM
Estimate against measurement, compound 3: 1.2-fold (0.07 log units) above; low and high end bracket the measured number.
By their numbers in this assay, from the lowest: compound 3; then compounds 2 and 1 (each within the scatter of the next).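

In this assay, this aromatic carbon now shows a step beyond the scatter: 4-fluorophenyl gives a 2.5-fold lower number from compound 2 to compound 3 (0.40 log units; beyond the scatter) and, in place of 4,4-dimethyl-2-oxopyrrolidin-1-yl, a 3.0-fold lower number from compound 1 to compound 3 (0.48 log units; beyond the scatter). The two 2-oxopyrrolidin-1-yl groups did not separate, so the position responds to this larger change of group, though only modestly. Nothing at hand explains the shift. Still open, going by these compounds, is whether the lower number follows from the fluorine, the six-membered aromatic ring or the loss of the lactam. Unsubstituted phenyl or a simple amine such as morpholine at this carbon would help separate these.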